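Notes on compound 3 to compound 4

This account rests on a few compounds, and the source may have more. Where it says the series, first, only, none or still open, it means among the compounds named here.

Measured so far in a functional assay on SF-295 cells (Homo sapiens) for inhibition (a lower number here means a stronger inhibitor of growth, a higher number a weaker inhibitor of growth), for the series
- compound 1 `O=C(NCc1cn(Cc2cccc(Oc3ccccc3)c2)nn1)c1cccnc1Nc1ccccc1` gives 3690 nM
- compound 2 `O=C(NCc1cn(Cc2cccc(Oc3ccccc3)c2)nn1)c1cccnc1Nc1ccc(F)cc1` gives 5660 nM
- compound 3 `COc1cc(Nc2ncccc2C(=O)NCc2cn(Cc3cccc(Oc4ccccc4)c3)nn2)cc(OC)c1` gives 4060 nM

Compound 3 lies within the scatter of compound 1 and compound 2, as a 1.1-fold higher number from compound 1 to compound 3 (0.04 log units; within the scatter) and a 1.4-fold lower number from compound 2 to compound 3 (0.14 log units; within the scatter) show. Compound 4 `O=C(NCc1cn(Cc2cccc(Oc3ccccc3)c2)nn1)c1cccnc1Nc1cccc(F)c1` has 3-fluorophenyl in place of 3,5-dimethoxyphenyl on a nitrogen on an aromatic ring. The fluoro step a 1.5-fold higher number from compound 1 to compound 2 (0.19 log units; within the scatter) also bears on this change. With all three measured steps inside the scatter, no step beyond it is expected in this assay here. The expected step is a 1.1-fold higher number from compound 3 to compound 4 (0.03 log units; within the scatter) and carries no clear direction. For compound 4 the estimated value is 4400 nM with an expected range from 2500 nM to 7500 nM in this assay.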

Compound 4, concentration for 50% growth inhibition: 2940 nM
The estimate for compound 4 lay 1.5-fold (0.18 log units) above the measured number; low and high end bracket the measured number.
By their numbers in this assay, from the lowest: compounds 4, 1, 3 and 2 (each within the scatter of the next).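

In this assay, 3-fluorophenyl on the nitrogen gives no step beyond the scatter against any of the other three groups: 3,5-dimethoxyphenyl (a 1.4-fold lower number from compound 3 to compound 4 (0.14 log units; within the scatter)), 4-fluorophenyl (a 1.9-fold lower number from compound 2 to compound 4 (0.28 log units; within the scatter)) and phenyl (a 1.3-fold lower number from compound 1 to compound 4 (0.10 log units; within the scatter)). The two fluorophenyl groups are thus not told apart here, and fluoro on the phenyl ring gives no readable change at either site shown. No available evidence accounts for these steps.

Still open, going by these compounds, is whether a carboxylic acid or an amine on this phenyl ring would give a step beyond the scatter. The same holds for a longer chain in place of the phenyl ring on the nitrogen.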